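The compounds below may be only part of what the source reports. "The series", "measured", "known", "first", "only" and "open" are said of these compounds alone.

Working notes on the series. Compound 1 `CC(=O)N1CCN(c2nc(Nc3ccc(C#N)c(C(F)(F)F)c3)nc(Oc3ccnc4ccccc34)n2)CC1` carries an acetyl on the ring amine nitrogen of the shared core. In a functional assay on DU-145 cells (Homo sapiens) for cytotoxicity, read by sulforhodamine B assay, with a stated time of 48 h (on this read-out lower numbers stand for higher toxicity in this test and higher numbers for lower toxicity in this test), compound 1 returns only a limit of the assay, > 100000 nM, and no number. Compound 2 `N#Cc1ccc(Nc2nc(Oc3ccnc4ccccc34)nc(N3CCN(C(c4ccccc4)c4ccccc4)CC3)n2)cc1C(F)(F)F` bears a diphenylmethyl on the same ring nitrogen. In this assay compound 2 also returns only a limit, > 100000 nM. Among the compounds with values here, compound 1 therefore stands at the limit of > 100000 nM in this assay, at which 2 of the 2 values shown sit; the two measured values show nothing more than that both compounds sit at the limit, so no step between measured compounds can be stated.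

Compound 3 `N#Cc1ccc(Nc2nc(Oc3ccnc4ccccc34)nc(N3CCN(c4ccccc4F)CC3)n2)cc1C(F)(F)F` has not yet been measured. It differs from compound 1 by 2-fluorophenyl in place of acetyl on an amine nitrogen in a ring. The 2-fluorophenyl thus takes the place of the acetyl on the amine nitrogen in the ring of the six-membered non-aromatic ring with 2 nitrogen.

Within the data shown here, no measured step exists to scale an expectation, and the two measured compounds give no number to move from. The step from compound 1 to compound 3 is expected to be a number no higher from compound 1 to compound 3 (the limit leaves the size open), that is none beyond the scatter, with a limit again the most probable report. For compound 3 the estimated value in this assay is 100000 nM, within a range from 30000 nM to 400000 nM.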

Compound 3, concentration lethal to 50% of the cells: > 100000 nM
Compound 3: a limit, no number; the forecaster's own chance of this, stated with the estimate: 75%; the middle value lies on the limit itself.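

Compound 3, like compound 1, returns only a limit and no number in this assay, so no step can be read from compound 1 to compound 3: the limit of > 100000 nM in this assay, at which 3 of the 3 values shown sit.

The compounds shown leave open how acetyl, diphenylmethyl and 2-fluorophenyl on the ring amine nitrogen rank against one another in this assay, and whether any group at that place gives a numerical value.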